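Compound 4 in the cytotoxicity read-out: an estimate

The source may report more compounds than this note shows. Statements on the series, on what has been measured and on what is new or still open speak of the compounds shown alone.

Measured so far in an ADME assay on BJ cells (Homo sapiens) for cytotoxicity, with a stated time of 72 h; on this read-out lower numbers stand for an effect already at smaller amounts and higher numbers for an effect only at larger amounts of compound:
Compound 1 `CCc1ccc(-c2nc3c(c(C)nn3-c3ccccc3)c(-c3ccccc3[N+](=O)[O-])c2C#N)cc1` gives a limit, > 20000 nM.
Compound 2 `Cc1ccccc1-c1nc2c(c(C)nn2-c2ccccc2)c(-c2ccccc2O)c1C#N` gives 21000 nM.
Compound 3 `Cc1nn(-c2ccccc2)c2nc(-c3ccc4ccccc4c3)c(C#N)c(-c3ccccc3O)c12` gives a limit, > 20000 nM.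

Compound 3 thus stands at the limit of this assay. Most of the values shown sit there: the limit of > 20000 nM in this assay, at which 2 of the 3 values shown sit. Among the measured compounds shown here, the one step into compound 3, a step that the limit leaves unreadable from compound 2 to compound 3, cannot be read as a size. Compound 4 `Cc1nn(-c2ccccc2)c2nc(-c3ccc4c(c3)OCCO4)c(C#N)c(-c3ccccc3O)c12` differs from compound 3 in one place: 2,3-dihydro-1,4-benzodioxin-6-yl in place of naphthalen-2-yl on an aromatic carbon. For the measured compounds named here, no measured step bears on this exchange, and the step leading to compound 3 is unreadable, so the expectation rests only on where compound 3 stands. Compound 4 is therefore expected to remain at the limit, with an estimated step of a number no higher from compound 3 to compound 4 (the limit leaves the size open). For compound 4 the estimate in this assay is 20000 nM, between 10000 nM and 40000 nM.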

Compound 4, half-maximal effective concentration: > 20000 nM
Compound 4 ended at the assay's limit; the forecaster's own chance of this, stated with the estimate: 70%; the middle value lies on the limit itself.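

No size can be read for the steps into compound 4 from compound 2 or compound 3, because these values meet a limit: the limit of > 20000 nM in this assay, at which 3 of the 4 values shown sit.

The compounds shown leave open what amounts of compound 1, compound 3 or compound 4 would produce an effect in this assay.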